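A few compounds are considered here, and "the series" means these few. Any claim that something is new, unique, unknown or untested is made for them only; others in the source may bear on it.

Compound 1 `COc1ccccc1-n1nncc1CN1C(=O)C2(C(C#N)=C(N)Oc3c2c2nc4ccccc4nc2c2ccccc32)c2ccccc21`: in a functional assay on HCT-116 cells (Homo sapiens) for antiproliferative activity, read by MTT assay, with a stated time of 48 h (a higher number here means a weaker inhibitor, a lower number a stronger inhibitor), compound 1 gives > 50000 nM, a limit of the assay rather than a number.
Compound 2 `N#CC1=C(N)Oc2c(c3nc4ccccc4nc3c3ccccc23)C12C(=O)N(Cc1cnnn1-c1ccc(N)cc1)c1ccccc12`: compound 2 gives 45200 nM.
Compound 3 `COc1ccccc1-n1nncc1CN1C(=O)C2(C(C#N)=C(N)Oc3c(N)cc4nc5ccccc5nc4c32)c2ccccc21`: compound 3 gives > 50000 nM, again a limit of the assay.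

Compound 3 therefore stands at the top of the measured range, with only a limit known for it, and two of the three values shown sit at the limit of > 50000 nM in this assay, at which 2 of the 3 values shown sit. Compound 4 `COc1ccc(OC)c(-n2nncc2CN2C(=O)C3(C(C#N)=C(N)Oc4c(N)cc5nc6ccccc6nc5c43)c3ccccc32)c1` differs from compound 3 by methoxy in place of hydrogen on an aromatic carbon. Within the data shown here, the only measured step, an at least 1.1-fold lower number from compound 1 to compound 2 (0.04 log units; that floor lies within the scatter), concerns the aryl on the aromatic nitrogen, not this aromatic carbon, and lies within the scatter. Among the measured compounds shown here, no measured step covers a methoxy added here. For compound 4 a step of a number no higher from compound 3 to compound 4 (the limit leaves the size open) is expected, that is none beyond the scatter, and the estimate for compound 4 is 50000 nM, within 20000 nM to 150000 nM, most likely reported again as a limit.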

Compound 4, half-maximal inhibitory concentration: > 50000 nM
Compound 4: a limit, no number; the forecaster's own chance of this, stated with the estimate: 70%; the middle value lies on the limit itself.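

Compound 3 and compound 4 are both known only as a limit of the assay in this assay, so no step can be read between them: the limit of > 50000 nM in this assay, at which 3 of the 4 values shown sit.

The compounds shown leave open how far 2-methoxyphenyl to 2,5-dimethoxyphenyl moves the number.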